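Urea in Place of Hydrazine on a Nitrile-Bearing Core

The compounds below may be only part of what the source reports. "The series", "measured", "known", "first", "only" and "open" are said of these compounds alone.

Compound 1, `N#Cc1c(NN)nc(SCc2nc3ccccc3[nH]2)nc1-c1ccccc1`: 11.9 nM
Compound 2, `N#Cc1c(NNC(N)=S)nc(SCc2nc3ccccc3[nH]2)nc1-c1ccccc1`: 4.54 nM

Among the two compounds measured in a functional assay on HL-60 cells (Homo sapiens) for cytotoxicity, read by MTT assay, with a stated time of 3 days (on this read-out higher numbers stand for weaker inhibition and lower numbers for stronger inhibition), compound 1 stands with the highest number, and its nearest neighbour is compound 2 at a 2.6-fold lower number from compound 1 to compound 2 (0.42 log units; beyond the scatter). Compound 3, `N#Cc1c(NC(N)=O)nc(SCc2nc3ccccc3[nH]2)nc1-c1ccccc1`, has not yet been measured; it differs from compound 1 by carbamoyl in place of amino on a nitrogen on an aromatic ring. Going by the values given here, the only measured step that bears on this change is the one from compound 1 to compound 2, where a group was added on the outer amine nitrogen and the number fell by a 2.6-fold lower number from compound 1 to compound 2 (0.42 log units; beyond the scatter). Compound 3 instead exchanges the amino group itself for carbamoyl, so that step is only a partial guide. Compound 3 is therefore expected to show a 1.5-fold lower number from compound 1 to compound 3 (0.17 log units; within the scatter), a modest lowering at most. The estimate for compound 3 is 8 nM, within 3 nM to 22 nM.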

Compound 3, half-maximal inhibitory concentration: 2.9 nM
Compound 3: the middle estimate sits 2.8-fold (0.44 log units) above what was measured; measured number below the stated range.
By their numbers in this assay, from the lowest: compounds 3 and 2 (each within the scatter of the next); then compound 1.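

In this assay, the lower number seen earlier did not depend on keeping the hydrazine-type link: carbamoyl in place of amino, on a nitrogen on an aromatic ring, also lowers the number (a 4.1-fold lower number from compound 1 to compound 3 (0.61 log units; beyond the scatter)), a step beyond the scatter. The sulfur-bearing group of compound 2 and the carbamoyl group of compound 3 cannot be told apart here (a 1.6-fold lower number from compound 2 to compound 3 (0.19 log units; within the scatter)), so the two replacements give matching results on this read-out. Nothing at hand accounts for this result.

Whether the amine nitrogen of the carbamoyl group is needed remains open, since an acetyl group on this nitrogen is not among the compounds shown. Also open, as far as these compounds go, is how a methyl group or a longer chain at this place would compare.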